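The compounds below may be only part of what the source reports. "The series", "measured", "known", "first", "only" and "open" are said of these compounds alone.

Compound 1 `FC(F)(F)c1ccc(CSc2nc(N3CCNCC3)cc(C(F)(F)F)n2)cc1`: 6210 nM
Compound 2 `FC(F)(F)c1ccc(CSc2nc(N3CCN(c4ccccc4)CC3)cc(C(F)(F)F)n2)cc1`: > 50000 nM (a limit, not a number)

Both results come from a functional assay on NCI-H1975 cells (Homo sapiens) for inhibition, read by MTT assay, with a stated time of 72 h; a higher number here means a weaker inhibitor, a lower number a stronger inhibitor. Compound 2 gives > 50000 nM in this assay, and this is a limit of the assay, so compound 2 has no exact value.

Compound 3 `CC(C)(C)OC(=O)N1CCN(c2cc(C(F)(F)F)nc(SCc3ccc(C(F)(F)F)cc3)n2)CC1` has not yet been measured. It differs from compound 2 in one place: tert-butoxycarbonyl in place of phenyl on an amine nitrogen in a ring. In words, this is tert-butoxycarbonyl in place of phenyl on an amine nitrogen in a ring.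

One measured step involves that same nitrogen: an at least 8.0-fold higher number from compound 1 to compound 2 (0.90 log units; beyond the scatter). There, phenyl replaced hydrogen, and the change lies beyond the scatter. For the measured compounds named here, no measured compound carries tert-butoxycarbonyl, so this step gives only indirect guidance. Compound 3, like compound 2, has a group other than hydrogen on that nitrogen. Given an at least 8.0-fold higher number from compound 1 to compound 2 (0.90 log units; beyond the scatter), a result closer to the limit than to the value of compound 1 seems likely, with a modest move towards a lower number from compound 2.

The expected change is an at least 2.0-fold lower number from compound 2 to compound 3 (0.30 log units; that floor lies within the scatter).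

For compound 3, the estimated value is 25000 nM, with an expected range from 9000 nM to 50000 nM.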

Compound 3, half-maximal inhibitory concentration: > 50000 nM
Compound 3: a limit, no number; the forecaster's own chance of this, stated with the estimate: 40%; at least 2.0-fold (0.30 log units) between middle value and limit.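

In this assay, replacing the hydrogen on the ring nitrogen with tert-butoxycarbonyl gives an at least 8.0-fold higher number from compound 1 to compound 3 (0.90 log units; beyond the scatter), a loss of the same printed size as the one seen with phenyl, an at least 8.0-fold higher number from compound 1 to compound 2 (0.90 log units; beyond the scatter). The earlier pair showed this for a single group with an aromatic ring, whereas tert-butoxycarbonyl has no ring and carries a carbonyl, so two quite different groups on this nitrogen now go the same way, and of the three compounds only compound 1, with hydrogen there, gives an exact value. The step between phenyl and tert-butoxycarbonyl cannot be read, because both results are limits: the limit of > 50000 nM in this assay, at which 2 of the 3 values shown sit.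

The compounds shown leave open whether a methyl or an acetyl group on that nitrogen would keep a value close to that of compound 1 or would also reach the limit. Also open, from the compounds shown here alone, is whether a group carrying an amine or a carboxylic acid at this position would give an exact value, and how compound 2 and compound 3 rank against each other.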